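Compound 4: 2-nitrophenyl for 1-methyl-1H-pyrazol-4-yl in compound 3

The compounds below may be only part of what the source reports. "The series", "measured", "known", "first", "only" and "open" are said of these compounds alone.

Measured so far:
compound 1 `Cc1nn(-c2nc(-c3ccc(Cl)c(Cl)c3)c(SC(C)C)s2)c(C(=O)O)c1Cc1ccccc1[N+](=O)[O-]` gives 20000 nM in a functional assay on BJAB cells (Homo sapiens) for antiproliferative activity, with a stated time of 4 days; a lower number here means that less compound is needed, a higher number that more compound is needed for the effect
compound 2 `CCOc1ncccc1-c1c(C)nn(-c2nc(-c3ccc(Cl)c(Cl)c3)c(SC(C)C)s2)c1C(=O)O` gives 11000 nM in this assay
compound 3 `Cc1nn(-c2nc(-c3ccc(Cl)c(Cl)c3)c(SC(C)C)s2)c(C(=O)O)c1-c1cnn(C)c1` gives 6800 nM in this assay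

Within the data shown here, compound 3 has the lowest of the three numbers, but its gap to compound 2 is within the scatter; only the step of a 2.9-fold lower number from compound 1 to compound 3 (0.47 log units; beyond the scatter) is beyond it, and that step is modest. The step of a 1.8-fold lower number from compound 1 to compound 2 (0.26 log units; within the scatter) is within the scatter.

Compound 4 `Cc1nn(-c2nc(-c3ccc(Cl)c(Cl)c3)c(SC(C)C)s2)c(C(=O)O)c1-c1ccccc1[N+](=O)[O-]` differs from compound 3 in one place: 2-nitrophenyl in place of 1-methyl-1H-pyrazol-4-yl on an aromatic carbon. Among the measured compounds shown here, the only step that bears on this is a 2.9-fold lower number from compound 1 to compound 3 (0.47 log units; beyond the scatter), where the entering group in compound 1 was 2-nitrobenzyl rather than 2-nitrophenyl. Reversing that step is expected to give a modest rise, a 1.9-fold higher number from compound 3 to compound 4 (0.28 log units; within the scatter), in this assay. Compound 4 is therefore estimated at 13000 nM, within 5000 nM to 32000 nM.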

Compound 4, half-maximal effective concentration: 4700 nM
Compound 4: the middle estimate sits 2.8-fold (0.44 log units) above what was measured; the measured number lies below the stated range.
By their numbers in this assay, from the lowest: compounds 4, 3, 2 and 1 (each within the scatter of the next, the first and the last beyond it).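

In this assay, 2-nitrophenyl and 1-methyl-1H-pyrazol-4-yl cannot be told apart at this position (a 1.4-fold lower number from compound 3 to compound 4 (0.16 log units; within the scatter)), so a six-membered aromatic ring of carbon only and a five-membered aromatic ring with 2 nitrogen both fit here. Against 2-ethoxypyridin-3-yl, 2-nitrophenyl gives a step beyond the scatter (a 2.3-fold lower number from compound 2 to compound 4 (0.37 log units; beyond the scatter)), the first such step among the groups joined by a ring directly. Joining the nitro-bearing ring directly rather than as 2-nitrobenzyl gives the largest step so far (a 4.3-fold lower number from compound 1 to compound 4 (0.63 log units; beyond the scatter)).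

No measurement available explains these steps. On these data alone, whether an amine or a longer chain at this position would go beyond these modest steps stays open.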